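Working notes: the group on the carbonyl carbon

The source may report more compounds than this note shows. Statements on the series, on what has been measured and on what is new or still open speak of the compounds shown alone.

Measured in a functional assay on COR-L23 cells (Homo sapiens) for antiproliferative activity, read by CellTiter-Glo, with a stated time of 72 h; on this read-out lower numbers stand for stronger inhibition and higher numbers for weaker inhibition:
- compound 1 `C[C@H](NC(=O)c1ncccn1)c1ccc(NC(=O)N2CC(c3cccnc3)C2)cc1`: 130 nM
- compound 2 `C[C@H](NC(=O)[C@@H]1CCCN1C)c1ccc(NC(=O)N2CC(c3cccnc3)C2)cc1`: 38 nM

Of the two measured compounds, compound 2 has the lower number, at 38 nM. The next compound to be measured is compound 3 `CCC(=O)N[C@@H](C)c1ccc(NC(=O)N2CC(c3cccnc3)C2)cc1`, which has ethyl in place of 1-methylpyrrolidin-2-yl on a carbonyl carbon.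

Among the measured compounds shown here, only one measured step bears on this change, and it falls at the same place: a 3.4-fold lower number from compound 1 to compound 2 (0.53 log units; beyond the scatter). This modest step shows that the group on this carbonyl carbon can move the number beyond the scatter. It offers only a rough guide, since both measured groups contain a ring and ethyl does not. For the measured compounds named here, no measured compound carries an open chain here, so the direction rests on weak evidence. Compound 2 already sits at the low end with 38 nM, so a modest rise in this assay seems more likely than a further fall.

The expected step is a 2.4-fold higher number from compound 2 to compound 3 (0.37 log units; beyond the scatter). For compound 3 the estimated value is 90 nM, with an expected range of 25 nM to 320 nM.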

Compound 3, half-maximal inhibitory concentration: 120 nM
Estimate against measurement, compound 3: 1.3-fold (0.12 log units) below; the measured number falls inside the stated range.
By their numbers in this assay, from the lowest: compound 2; then compounds 3 and 1 (each within the scatter of the next).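

Ethyl brings the first open chain onto this carbonyl carbon, and in this assay replacing 1-methylpyrrolidin-2-yl with it gives a 3.2-fold higher number from compound 2 to compound 3 (0.50 log units; beyond the scatter). Replacing pyrimidin-2-yl with ethyl gives a 1.1-fold lower number from compound 1 to compound 3 (0.03 log units; within the scatter), so these two groups cannot be told apart here, and the presence of a ring does not by itself separate the three compounds; among them, only compound 2, carrying 1-methylpyrrolidin-2-yl, stands apart, with the lowest number. No data are available here to account for this difference.

Which part of 1-methylpyrrolidin-2-yl goes with the lower number remains open: the set does not show whether pyrrolidin-2-yl without the methyl, the opposite configuration at the defined stereocentre, or a piperidin-2-yl ring would match compound 2. Nor does it show how an open-chain amine such as dimethylaminomethyl, or a chain longer than ethyl such as butyl, would compare at this carbonyl carbon, which would help separate the amine from the ring.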